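A nitro swap at the limit of the cytotoxicity read-out

A few compounds are considered here, and "the series" means these few. Any claim that something is new, unique, unknown or untested is made for them only; others in the source may bear on it.

Measured in an ADME assay on BJ cells (Homo sapiens) for cytotoxicity, with a stated time of 72 h (a higher number here means that more compound is needed for the effect, a lower number that less compound is needed), so far
Compound 1 `CSc1ccccc1NC(=O)Nc1cc(C)nc2ccccc12` gives > 25000 nM as a limit
Compound 2 `COc1ccccc1NC(=O)Nc1cc(C)nc2ccccc12` gives > 25000 nM as a limit
Compound 3 `Cc1cc(NC(=O)Nc2ccccc2C(F)(F)F)c2ccccc2n1` gives > 25000 nM as a limit

In this assay compound 3 stands at > 25000 nM which is a limit and not a number. Across the series the record reads the limit of > 25000 nM in this assay, at which 3 of the 3 values shown sit, and nothing finer.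

Compound 4 `Cc1cc(NC(=O)Nc2ccccc2[N+](=O)[O-])c2ccccc2n1` differs from compound 3 in one group: nitro in place of trifluoromethyl on an aromatic carbon and so nitro takes the place of trifluoromethyl on an aromatic carbon.

Three measured swaps bear on this: a step that the two limits leave unreadable from compound 1 to compound 2 then a step that the two limits leave unreadable from compound 1 to compound 3 then a step that the two limits leave unreadable from compound 2 to compound 3 and none gives a size to carry over. No shift beyond the scatter is therefore expected in this assay and the expected a number no higher from compound 3 to compound 4 (the limit leaves the size open) has no set direction.

Compound 4 is estimated at 25000 nM with an expected range from 12000 nM to 50000 nM and will probably be reported only as a limit.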

Compound 4, half-maximal effective concentration: > 25000 nM
Compound 4 ended at the assay's limit (the forecaster's own chance of this, stated with the estimate: 75%); the middle value sits exactly at the limit.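

No step can be read between compound 4 and compounds 1, 2 or 3, because all four stand at one limit and not at a number: the limit of > 25000 nM in this assay, at which 4 of the 4 values shown sit. The compounds shown leave open whether any of these swaps changes the read-out in this assay, and by how much.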